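A few compounds are considered here, and "the series" means these few. Any claim that something is new, unique, unknown or untested is made for them only; others in the source may bear on it.

Measured compounds:
compound 1 `COc1cc(C)cc(-c2c(-c3ccnc(-c4ccc(C(C)=O)cc4)c3)cnn2CC#N)c1` — in a functional assay on NCI-H460 cells (Homo sapiens) for inhibition, read by sulforhodamine B assay, with a stated time of 48 h (a higher number here means that more compound is tolerated, a lower number that less compound is tolerated), compound 1 gives > 100000 nM
compound 2 `COc1cc(C)cc(-c2nn(CC#N)cc2-c2ccc(-c3cccc(C(C)=O)c3)nc2)c1` — compound 2 gives 26600 nM
compound 3 `Cc1cc(O)cc(-c2nn(CC#N)cc2-c2ccnc(-c3ccc(Oc4ccccc4)cc3)c2)c1` — compound 3 gives 6850 nM.

Compound 1 has no number from the assay, only a limit: the limit of > 100000 nM in this assay, at which 1 of the 3 values shown sits. On the values shown, compound 1 therefore stands at the end where the most compound is tolerated, without a figure of its own. Compounds 2 and 3 do give measured numbers, which shows that members of this family can reach a readable value.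

Compound 4 `COc1cc(C)cc(-c2c(-c3ccnc(-c4ccc(N(C)C)cc4)c3)cnn2CC#N)c1` has not been measured. Relative to compound 1 the change is dimethylamino in place of acetyl on an aromatic carbon. Among the compounds with values here, no pair of measured compounds shows this change, so its size can only be guessed. The expected step of an at least 1.6-fold lower number from compound 1 to compound 4 (0.22 log units; that floor lies within the scatter) is a small move toward less compound tolerated, possibly within the scatter, with a fair chance that only another limit is reported. For compound 4 the estimated value is 60000 nM, within the range 15000 nM to 200000 nM.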

Compound 4, concentration lethal to 50% of the cells: 4990 nM
Estimate against measurement, compound 4: 12-fold (1.08 log units) above; measured number outside the range, below it.
By their numbers in this assay, from the lowest: compounds 4 and 3 (each within the scatter of the next); then compound 2. At a limit, above all of these: compound 1.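

Exchanging 4-acetylphenyl for 4-(dimethylamino)phenyl gives, in this assay, an at least 20-fold lower number from compound 1 to compound 4 (1.30 log units; beyond the scatter), so what this position carries can matter a great deal on the core of compound 1. The two groups have the same count of heavy atoms and of hydrogen-bond acceptors, and neither carries a net charge, so a large move can occur even where these counts stay the same. Compound 1 has a limit and not a number, so the full size of the step cannot be read: the limit of > 100000 nM in this assay, at which 1 of the 4 values shown sits.

The compounds shown cannot separate an effect of gaining dimethylamino from an effect of losing acetyl. A primary amine or a methoxy group at this same position would bear on that question, while compounds 2 and 3 differ from compound 4 in more than one place and cannot settle it.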